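Methyl on the Ring Amide Nitrogen: What to Expect

The compounds below may be only part of what the source reports. "The series", "measured", "known", "first", "only" and "open" are said of these compounds alone.

Measured so far in a functional assay for inhibition, with Homo sapiens as the target; a higher number here means that more compound is needed for the effect, a lower number that less compound is needed:
- compound 1, `Nc1ccc(C2=NNC(=O)CC2)cc1`: 46.4 ug/mL
- compound 2, `CN1N=C(c2ccc(N)cc2)CCC1=O`: > 46.4 ug/mL, which is a limit of the assay, not a number
- compound 3, `O=C1CCC(c2ccc(NC(=O)CCl)cc2)=NN1`: 0.39 ug/mL

Compound 1 and compound 3 share a core and differ in one place: (chloromethyl)carbonyl in place of hydrogen on a nitrogen on an aromatic ring. That single change gave a 120-fold lower number from compound 1 to compound 3 (2.08 log units; beyond the scatter), so compound 3 sits lowest among the numbers at hand.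

Compound 2 differs from compound 1 by methyl in place of hydrogen on an amide-type nitrogen in a ring. From the compounds shown here alone, the step was a number no lower from compound 1 to compound 2 (the limit leaves the size open); the result for compound 2 stands at the limit of > 46.4 ug/mL in this assay, at which 1 of the 3 values shown sits, so the true size of the step stays open.

Compound 4, `CN1N=C(c2ccc(NC(=O)CCl)cc2)CCC1=O`, has not yet been measured. It differs from compound 3 by methyl in place of hydrogen on an amide-type nitrogen in a ring. Among the measured compounds shown here, this is the same kind of change as the one from compound 1 to compound 2; the surroundings are described slightly differently, the ring atom two bonds away bearing a group of 7 heavy atoms in the first case and a large group in the second.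

For this assay the step is expected to be a 6.4-fold higher number from compound 3 to compound 4 (0.81 log units; beyond the scatter), resting on compound 1 to compound 2 having given a number no lower from compound 1 to compound 2 (the limit leaves the size open). Compound 4 is therefore estimated at 2.5 ug/mL, with a range from 0.5 ug/mL to 15 ug/mL expected.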

Compound 4, half-maximal effective concentration: > 46.4 ug/mL
Compound 4 was reported as a limit; the forecaster's own chance of this, stated with the estimate: 10%; middle value at least 18-fold (1.26 log units) away from the limit.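

In this assay, methyl in place of hydrogen on the amide-type nitrogen in the ring gave an at least 110-fold higher number from compound 3 to compound 4 (2.07 log units; beyond the scatter), so on the core carrying (chloromethyl)carbonyl this single added carbon removes the low number that compound 3 had. Compound 4 stands at > 46.4 ug/mL, which is a limit of the assay and not a number, so the true size of this step could be larger still. The change gave no lower number on either core, but this rests on only two pairs, and the step from compound 1 to compound 2 and the step from compound 2 to compound 4 cannot be read, so the data do not show that the change has the same size on both cores: the same change on two cores in this assay, a number no lower (the limit leaves the size open) from compound 1 to compound 2 and an at least 110-fold higher number (2.07 log units; beyond the scatter) from compound 3 to compound 4; the limit leaves it open whether they differ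

The compounds shown leave open whether the loss follows from methyl in particular or would also appear with ethyl or a longer chain on that ring nitrogen. They also leave open whether an acetyl group or a carboxylic acid in place of the (chloromethyl)carbonyl would give a low number, and whether methyl on the ring nitrogen would then have a readable effect.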